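The source may hold more compounds than are shown below. What is called first, only, known or untested is meant among the compounds shown, and "the series" means these compounds.

Four close relatives built on one shared core are compared here. Compound 1 `Nc1nc(Cl)c2ncn(Cc3ccc(CCl)cc3)c2n1` and compound 3 `ClCc1ccc(Cn2cnc3c(Cl)nc(Cl)nc32)cc1` differ from each other in a single group, as do compound 2 `ClCc1cccc(Cn2cnc3c(Cl)nc(Cl)nc32)c1` and compound 4 `Nc1nc(Cl)c2ncn(Cc3cccc(CCl)c3)c2n1`. Compound 2 and compound 3 are made of the same atoms joined differently, and the difference between the two cores is not broken down here.

Growth inhibition was measured in a functional assay on SK-OV-3 cells (Homo sapiens) for cytotoxicity, read by sulforhodamine B assay, with a stated time of 48 h; on this read-out higher numbers stand for weaker inhibition of growth and lower numbers for stronger inhibition of growth. In this assay compound 3 gives 13500 nM, and compound 1 gives 15100 nM. From the compounds shown here alone, for compound 2 this assay returned "not determined" (no result reported), so its own starting point is unknown.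

The change from compound 3 to compound 1 is amino in place of chloro on an aromatic carbon, and it produced a 1.1-fold higher number from compound 3 to compound 1 (0.05 log units; within the scatter). The same change, at a place described in the same words, leads from compound 2 to compound 4: amino in place of chloro on an aromatic carbon. With no number for compound 2, the expectation for compound 4 cannot be built as a step from compound 2; it rests instead on the fact that compound 3 gives 13500 nM and that the same change gave a 1.1-fold higher number from compound 3 to compound 1 (0.05 log units; within the scatter), so a result near the two measured compounds is expected, though a rearranged core may shift it. Compound 4 is therefore expected to give about 14000 nM in this assay, estimated to fall between 6000 nM and 32000 nM.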

Compound 4, concentration for 50% growth inhibition: 24000 nM
Estimate against measurement, compound 4: 1.7-fold (0.23 log units) below; low and high end bracket the measured number.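

Compound 2 has no single number in this assay, and the step from it to compound 4 cannot be read. What the compounds shown leave open is whether amino in place of chloro on an aromatic carbon acts on the core of compound 2 as it does on the core of compound 3. No supporting data shown here explain the result for compound 4.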